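From pyridin-3-yl to pyridin-4-yl in compound 1

The source may hold more compounds than are shown below. What is called first, only, known or untested is meant among the compounds shown, and "the series" means these compounds.

Measured so far in a functional assay on QGY-7703 cells (Homo sapiens) for cytotoxicity, read by MTT assay, with a stated time of 24 h; on this read-out higher numbers stand for weaker inhibition and lower numbers for stronger inhibition
- Compound 1 `CN1C/C(=C\c2cccnc2)C(=O)/C(=C/c2ccccc2F)C1` gives 4470 nM
- Compound 2 `CN1C/C(=C\c2cccnc2)C(=O)/C(=C/c2ccc(F)cc2Br)C1` gives 2610 nM
- Compound 3 `CN1C/C(=C\c2cccnc2)C(=O)/C(=C/c2ccccc2C(F)(F)F)C1` gives 2910 nM

Compound 1 stands within the usual scatter of both other compounds, so its number does not set it apart. Compound 4 `CN1C/C(=C\c2ccncc2)C(=O)/C(=C/c2ccccc2F)C1` keeps the core of compound 1 and changes one group: pyridin-4-yl in place of pyridin-3-yl on a double-bonded chain carbon bound to a double-bonded ring carbon. Here pyridin-4-yl takes the place of pyridin-3-yl on a double-bonded chain carbon bound to a double-bonded ring carbon.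

Two measured steps start from compound 1, a 1.7-fold lower number from compound 1 to compound 2 (0.23 log units; within the scatter) and a 1.5-fold lower number from compound 1 to compound 3 (0.19 log units; within the scatter). Both leave pyridin-3-yl in place, so neither tests this change directly. With only those small steps as a guide, no step beyond the scatter is expected in this assay, and no firm direction. The expected step is a 1.1-fold lower number from compound 1 to compound 4 (0.05 log units; within the scatter). In this assay the estimated value for compound 4 is 4000 nM, with an expected range from 1600 nM to 10000 nM.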

Compound 4, half-maximal inhibitory concentration: 4900 nM
Compound 4: the middle estimate sits 1.2-fold (0.09 log units) below what was measured; the measured number falls inside the stated range.
By their numbers in this assay, from the lowest: compounds 2, 3, 1 and 4 (each within the scatter of the next).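

Among the compounds shown here, this is the first compound in the set to vary the pyridine group rather than the other aryl group on the shared core. In this assay, pyridin-4-yl in place of pyridin-3-yl gives a 1.1-fold higher number from compound 1 to compound 4 (0.04 log units; within the scatter), so with 2-fluorophenyl kept, this read-out does not distinguish these two pyridinyl groups on a double-bonded chain carbon bound to a double-bonded ring carbon. Nothing available on these compounds offers an explanation for this result.

The compounds shown leave open whether a plain phenyl group, or a phenyl group carrying an amine or a carboxylic acid, would give a similar number at this place. They also leave open whether pyridin-4-yl and pyridin-3-yl would remain indistinguishable alongside 2-bromo-4-fluorophenyl.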